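Removing diethylcarbamoyl from the ring amine nitrogen

The source may report more compounds than this note shows. Statements on the series, on what has been measured and on what is new or still open speak of the compounds shown alone.

In an in vitro ADME assay on microsomes from liver (Mus musculus) for pharmacokinetics, read by LC-MS, with a stated time of 10 min, tested at 1 uM (on this read-out higher numbers stand for fast clearance and lower numbers for slow clearance), compound 2 `CCN(CC)C(=O)N1C[C@H](C(=O)Nc2ccc(Cl)cc2)[C@@H](c2ccc(/C=C/C(=O)Nc3ccccc3N)cc2)C1` gives 83 mL/min/kg, the higher of the two numbers, and compound 1 `CC(C)(CO)N1C[C@H](C(=O)Nc2ccc(Cl)cc2)[C@@H](c2ccc(/C=C/C(=O)Nc3ccccc3N)cc2)C1` gives 40 mL/min/kg. Compound 3 `Nc1ccccc1NC(=O)/C=C/c1ccc([C@H]2CN(C3CCOCC3)C[C@@H]2C(=O)Nc2ccc(Cl)cc2)cc1` carries oxan-4-yl in place of diethylcarbamoyl on an amine nitrogen in a ring. Among the measured compounds shown here, only one measured step bears on this place: a 2.1-fold higher number from compound 1 to compound 2 (0.32 log units; beyond the scatter), modest in size, with diethylcarbamoyl entering. Compound 3 gives up that same group, so a modestly lower number in this assay is expected, possibly within the scatter. The expected step is a 1.5-fold lower number from compound 2 to compound 3 (0.18 log units; within the scatter). Compound 3 is estimated at 55 mL/min/kg, with an expected range of 25 mL/min/kg to 110 mL/min/kg.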

Compound 3, clearance: 44 mL/min/kg
Compound 3: the middle estimate sits 1.3-fold (0.10 log units) above what was measured; the measured number falls inside the stated range.
By their numbers in this assay, from the lowest: compounds 1, 3 and 2 (each within the scatter of the next, the first and the last beyond it).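

At this amine nitrogen in a ring, oxan-4-yl gives a 1.9-fold lower number from compound 2 to compound 3 (0.28 log units; within the scatter) in this assay, and against 1-(hydroxymethyl)-1-methylethyl it gives a 1.1-fold higher number from compound 1 to compound 3 (0.04 log units; within the scatter). A group with a six-membered non-aromatic ring therefore lies within the scatter of both earlier groups, although those two groups lie beyond the scatter of each other. Nothing available explains these numbers.

Still open, from the compounds shown here alone, is how a carboxylic acid or a primary amine at this nitrogen would read in this assay. Also open, going by these compounds, is whether a shorter acyl chain would read nearer to compound 2 or to compound 3.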